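The compounds below may be only part of what the source reports. "The series", "measured", "known", "first", "only" and "open" are said of these compounds alone.

Measured in an ADME assay on Jurkat cells (Homo sapiens) for cytotoxicity, read by trypan blue exclusion, with a stated time of 24 h; a lower number here means a stronger inhibitor, a higher number a weaker inhibitor:
- compound 1 `N#C[Se]Cc1ccc(Br)cc1`: 12700 nM
- compound 2 `N#C[Se]Cc1ccc(C(F)(F)F)cc1`: 7310 nM

Compound 2, at 7310 nM, cannot be told apart from compound 1, since a 1.7-fold lower number from compound 1 to compound 2 (0.24 log units; within the scatter) stays within the scatter of this assay. Among the measured compounds shown here, that step, trifluoromethyl in place of bromo on an aromatic carbon, is the only measured guide to the next change. Compound 3 `CSc1ccc(C[Se]C#N)cc1` carries methylsulfanyl in place of trifluoromethyl on an aromatic carbon. One small step is thin evidence, but no shift beyond the scatter is expected. The expected change is a 1.2-fold higher number from compound 2 to compound 3 (0.09 log units; within the scatter). For compound 3 the estimated value is 9000 nM, with an expected range of 4000 nM to 20000 nM.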

Compound 3, half-maximal inhibitory concentration: 5070 nM
Beside the measured number, compound 3's estimate is 1.8-fold (0.25 log units) above it; measured number inside the range.
By their numbers in this assay, from the lowest: compounds 3, 2 and 1 (each within the scatter of the next, the first and the last beyond it).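

In this assay, changing the group on this aromatic carbon now gives a step beyond the scatter, with a 2.5-fold lower number from compound 1 to compound 3 (0.40 log units; beyond the scatter) for methylsulfanyl in place of bromo. By contrast, a 1.4-fold lower number from compound 2 to compound 3 (0.16 log units; within the scatter) shows that methylsulfanyl in place of trifluoromethyl cannot be told apart, so compound 3 separates only from compound 1. Nothing measured here accounts for either step. Still open, going by these compounds, is how an amine or a carboxylic acid on this carbon would compare. A longer sulfur-bearing chain in place of methylsulfanyl is equally untested in the compounds shown.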